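Thiophen-2-yl in place of phenyl on compound 1

The source may report more compounds than this note shows. Statements on the series, on what has been measured and on what is new or still open speak of the compounds shown alone.

Measured in a functional assay on HCT-15 cells (Homo sapiens) for antiproliferative activity (on this read-out higher numbers stand for weaker inhibition of growth and lower numbers for stronger inhibition of growth), so far:
compound 1 `c1ccc(-c2cc(-c3cccnc3)nc(-c3ccccn3)c2)cc1` gives 40.9 ug/mL 
compound 2 `c1ccc(-c2cc(-c3ccccn3)nc(-c3ccccn3)c2)cc1` gives 0.37 ug/mL 
compound 3 `c1ccc(-c2cc(-c3ccco3)cc(-c3ccccn3)n2)nc1` gives 0.1 ug/mL 

Compound 1 has the highest number of the three. Compound 4 `c1ccc(-c2cc(-c3cccs3)cc(-c3cccnc3)n2)nc1` is unmeasured and differs from it by thiophen-2-yl in place of phenyl on an aromatic carbon opposite the ring nitrogen. Going by the values given here, the closest precedent, furan-2-yl in place of phenyl, gave a 3.7-fold lower number from compound 2 to compound 3 (0.57 log units; beyond the scatter) and that modest step was seen with pyridin-2-yl rather than pyridin-3-yl present. The large 110-fold lower number from compound 1 to compound 2 (2.04 log units; beyond the scatter) concerns a pyridinyl change that compound 4 does not make. The expected step is therefore modest, a 3.4-fold lower number from compound 1 to compound 4 (0.53 log units; beyond the scatter) in this assay with stronger inhibition of growth. Compound 4 is estimated at 12 ug/mL with an expected range of 3 ug/mL to 45 ug/mL for now.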

Compound 4, concentration for 50% growth inhibition: 56.1 ug/mL
Compound 4: the middle estimate sits 4.7-fold (0.67 log units) below what was measured, outside the stated range (above it).
By their numbers in this assay, from the lowest: compound 3; then compound 2; then compounds 1 and 4 (each within the scatter of the next).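

In this assay, thiophen-2-yl in place of phenyl opposite the ring nitrogen, with the pyridin-3-yl group kept, gives a 1.4-fold higher number from compound 1 to compound 4 (0.14 log units; within the scatter), so this five-membered ring alone brings no clear shift at this position. The earlier furan-2-yl step, a 3.7-fold lower number from compound 2 to compound 3 (0.57 log units; beyond the scatter), came with pyridin-2-yl present, and the two steps differ in both the entering ring and the pyridinyl setting. No available evidence bears on why this step stays so small.

Still open, from the compounds shown here alone, is whether thiophen-2-yl with pyridin-2-yl present would follow the furan-2-yl step. Also open, going by these compounds, is how an amine or a carboxylic acid on this carbon would read.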